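From Propanoylamino Back to a Methylpiperazine

The source may hold more compounds than are shown below. What is called first, only, known or untested is meant among the compounds shown, and "the series" means these compounds.

Going by the values given here, in a functional assay on BaF3 cells (Mus musculus) for inhibition, read by CCK-8 assay, with a stated time of 72 h (on this read-out lower numbers stand for stronger inhibition of growth and higher numbers for weaker inhibition of growth), compound 2 `CCC(=O)Nc1cc(Oc2ccc(NC(=O)Nc3ccc(C)c(C(F)(F)F)c3)cc2)ncn1` gives 990 nM, the lowest number so far, while compound 1 `Cc1ccc(NC(=O)Nc2ccc(Oc3cc(N4CCNC[C@H]4C)ncn3)cc2)cc1C(F)(F)F` gives 9670 nM. Compound 3 `Cc1ccc(NC(=O)Nc2ccc(Oc3cc(N4CCN[C@H](C)C4)ncn3)cc2)cc1C(F)(F)F` makes the next change on the shared core: 3-methylpiperazin-1-yl in place of propanoylamino on an aromatic carbon. In short, 3-methylpiperazin-1-yl stands in place of propanoylamino on an aromatic carbon.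

Among the compounds with values here, one measured step bears on this change, and it runs the opposite way: a 9.8-fold lower number from compound 1 to compound 2 (0.99 log units; beyond the scatter). In that step, propanoylamino took the place of 2-methylpiperazin-1-yl on an aromatic carbon. Within the data shown here, no measured compound carries 3-methylpiperazin-1-yl, so the data do not show how closely it will track 2-methylpiperazin-1-yl. Even so, much of that earlier step is expected to be reversed in this assay, giving a higher number and weaker inhibition of growth, though perhaps not all of it. The expected change is a 5.1-fold higher number from compound 2 to compound 3 (0.70 log units; beyond the scatter). For compound 3 the estimate is 5000 nM, with an expected range from 1800 nM to 14000 nM.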

Compound 3, concentration for 50% growth inhibition: 8920 nM
Compound 3: the middle estimate sits 1.8-fold (0.25 log units) below what was measured; low and high end bracket the measured number.
By their numbers in this assay, from the lowest: compound 2; then compounds 3 and 1 (each within the scatter of the next).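

The new result shows that the advantage of propanoylamino at this position is not tied to one methylpiperazine: in this assay, replacing it with 3-methylpiperazin-1-yl gives a 9.0-fold higher number from compound 2 to compound 3 (0.95 log units; beyond the scatter), about the same size as the earlier step with 2-methylpiperazin-1-yl, read in reverse. The two methylpiperazine isomers are not told apart in this assay, with a 1.1-fold lower number from compound 1 to compound 3 (0.04 log units; within the scatter), so among these three compounds the choice between propanoylamino and a methylpiperazine matters, while the change from 2-methylpiperazin-1-yl to 3-methylpiperazin-1-yl does not show up beyond the scatter. Nothing available explains why propanoylamino gives the lower number at this position.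

The compounds shown leave open whether the methyl group on the piperazine has any part in the higher numbers, which piperazin-1-yl without a methyl or morpholin-4-yl at the same aromatic carbon could help to settle. They also leave open how far the lower number of compound 2 depends on the propanoyl chain itself, a question that acetylamino or the longer butanoylamino would address.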